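The source may report more compounds than this note shows. Statements on the series, on what has been measured and on what is new or still open speak of the compounds shown alone.

Measured in an assay on cells for inhibition of Ectonucleotide pyrophosphatase/phosphodiesterase family member 1 (Homo sapiens), with a stated time of 60 min; a lower number here means a stronger inhibitor, a higher number a weaker inhibitor:
compound 1 `COc1cc2nc(/C=C/c3ccncc3)nc(N3CCC(CCNS(N)(=O)=O)CC3)c2cc1OC` — 218 nM
compound 2 `COc1ccccc1/C=C/c1nc(N2CCC(CCNS(N)(=O)=O)CC2)c2cc(OC)c(OC)cc2n1` — 302 nM
compound 3 `COc1ccc(/C=C/c2nc(N3CCC(CCNS(N)(=O)=O)CC3)c3cc(OC)c(OC)cc3n2)cc1` — 231 nM

Compound 1 gives the lowest of the three numbers in this assay, but its margins are slim: a 1.1-fold higher number from compound 1 to compound 3 (0.03 log units; within the scatter) and a 1.4-fold higher number from compound 1 to compound 2 (0.14 log units; within the scatter), so nothing separates the three compounds. The third pair behaves alike, a 1.3-fold lower number from compound 2 to compound 3 (0.12 log units; within the scatter).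

Compound 4 `COc1cc2nc(CCc3ccc(F)cc3)nc(N3CCC(CCNS(N)(=O)=O)CC3)c2cc1OC` is the next step from compound 1. The change is 2-(4-fluorophenyl)ethyl in place of 2-(pyridin-4-yl)ethenyl on an aromatic carbon. Only part of this has precedent: the three measured steps all swap the aromatic ring on the 2-(pyridin-4-yl)ethenyl group, and none moves the number beyond the scatter, so the exchange of pyridin-4-yl for a fluorophenyl ring by itself should cost little. Among the compounds with values here, the loss of the double bond outside aromatic rings, giving the 2-(4-fluorophenyl)ethyl chain, has no counterpart among the measured compounds, and nothing here says how much it matters. The expectation for compound 4 in this assay is therefore a small step, a 1.6-fold higher number from compound 1 to compound 4 (0.21 log units; within the scatter), most likely towards a somewhat higher number, with a broad range. Compound 4 is estimated at 350 nM, between 120 nM and 1100 nM.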

Compound 4, inhibition constant: 366 nM
For compound 4 the middle estimate is 1.0-fold (0.02 log units) below the measured one, and the stated range covers the measured number.
By their numbers in this assay, from the lowest: compounds 1, 3, 2 and 4 (each within the scatter of the next).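

In this assay, the aromatic carbon between two ring nitrogen atoms tolerates more than a swap of the aromatic ring: the double bond outside aromatic rings can go as well, with a 1.7-fold higher number from compound 1 to compound 4 (0.23 log units; within the scatter), a 1.6-fold higher number from compound 3 to compound 4 (0.20 log units; within the scatter) and a 1.2-fold higher number from compound 2 to compound 4 (0.08 log units; within the scatter). Compound 4 therefore stays within the scatter of all three ethenyl compounds, so within this set the double bond is not required to keep the number in this range. Nothing available explains this tolerance.

From the compounds shown here alone, compound 4 changes the chain and the ring together, so the separate share of each remains open. Also open, going by these compounds, is whether an amine, a carboxylic acid or a longer chain in place of 2-(4-fluorophenyl)ethyl would move the number beyond the scatter.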